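This account rests on a few compounds, and the source may have more. Where it says the series, first, only, none or still open, it means among the compounds named here.

Measured so far:
compound 1, `COc1ccc(-c2c(Br)c(=O)c3c(OC)cc(OC)cc3n2S(=O)(=O)c2ccc(OC)cc2)cc1`, 2580 nM
compound 2, `COc1ccc(-c2cc(=O)c3c(OC)cc(OC)cc3n2S(=O)(=O)c2cccc([N+](=O)[O-])c2)cc1`, > 39600 nM
compound 3, `COc1ccc(-c2cc(=O)c3c(OC)cc(OC)cc3n2S(=O)(=O)c2c(F)c(F)c(F)c(F)c2F)cc1`, > 34400 nM

For the measured compounds named here, in a functional assay on KOPN-8 cells (Homo sapiens) for antiproliferative activity, with a stated time of 72 h (on this read-out higher numbers stand for an effect only at larger amounts of compound and lower numbers for an effect already at smaller amounts), compound 1 gives the only number of the three; the other two values are limits of the assay. Compound 2 reaches only a limit, > 39600 nM. Compound 3 likewise reaches only a limit, > 34400 nM. Going by the values given here, the one step between measured compounds that differ in a single place, a step that the two limits leave unreadable from compound 2 to compound 3, changes the aryl on the sulfonyl sulfur and is unreadable between the two limits, so it says nothing about the size of any change.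

Compound 4, `COc1ccc(-c2cc(=O)c3c(OC)cc(OC)cc3n2S(=O)(=O)c2ccc(OC)cc2)cc1`, differs from compound 1 in one place: hydrogen in place of bromo on an aromatic carbon. Among the compounds with values here, no measured step concerns the bromo position, so the size of the change has no direct precedent here. Compounds 2 and 3 also lack the bromo, but each carries a different sulfonyl aryl as well, so their limits cannot be read as the effect of the bromo alone. The expectation for compound 4 rests on the bromo removal itself; the estimated step of a 3.1-fold higher number from compound 1 to compound 4 (0.49 log units; beyond the scatter) is expected to run toward weaker potency, with wide uncertainty. Compound 4 is therefore estimated at 8000 nM, within 2000 nM to 40000 nM.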

Compound 4, half-maximal effective concentration: > 82700 nM
Compound 4 was reported as a limit; the forecaster's own chance of this, stated with the estimate: 30%; middle value at least 10-fold (1.01 log units) from the limit.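

In this assay, for the compounds shown here, with the (4-methoxyphenyl)sulfonyl group and the rest of the core unchanged, the first direct reading at this position shows that hydrogen in place of bromo gives an at least 32-fold higher number from compound 1 to compound 4 (1.50 log units; beyond the scatter). Compound 4 reaches only a limit, > 82700 nM. No measured property at hand accounts for this step.

The steps among compound 2, compound 3 and compound 4 cannot be read, so the aryl groups on the sulfonyl sulfur stay unranked in the absence of the bromo. Open too, from the compounds shown here alone, is what chloro, a nitrile or an amine would give at this aromatic carbon, and whether the bromo has a similar effect with 3-nitrophenyl or 2,3,4,5,6-pentafluorophenyl on the sulfonyl sulfur.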